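The compounds below may be only part of what the source reports. "The series", "measured", "known", "first", "only" and "open" are said of these compounds alone.

Working notes on the cytotoxicity series.

Compound 1 `CC[C@H](CCn1cncn1)c1ccc(OC)cc1` gives 153 ug/mL in an ADME assay on HEp-2 cells (Homo sapiens) for cytotoxicity, read by MTT assay, with a stated time of 3 days; on this read-out lower numbers stand for higher toxicity in this test and higher numbers for lower toxicity in this test. Going by the values given here, compound 2 `CCC[C@H](CCn1cncn1)c1ccc(OC)cc1` gives 59.6 ug/mL in this assay, and the step of a 2.6-fold lower number from compound 1 to compound 2 (0.41 log units; beyond the scatter) is the only single-point change measured so far. Compound 3 `CCCC[C@H](CCn1cncn1)c1ccc(Cl)cc1` gives 20.2 ug/mL in this assay, the lowest of the three numbers: compound 2 stands above it and compound 1 further still, both gaps beyond the scatter. Among the compounds with values here, compound 3 differs from compound 2 in two places at once, so the two values show only that the pair with the longer chain and chloro is the more toxic.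

Compound 4 `CCCC[C@H](CCn1cncn1)c1ccc(OC)cc1` is not yet measured in this assay. It differs from compound 3 by methoxy in place of chloro on an aromatic carbon. Within the data shown here, no measured step covers a methoxy-for-chloro exchange, so the direction must be inferred from the rest. Compound 4 keeps the chain of compound 3 and the methoxy of compound 2, and with compound 2 at 59.6 ug/mL and the chain lengthening a 2.6-fold lower number from compound 1 to compound 2 (0.41 log units; beyond the scatter), compound 4 is expected to sit between those two, giving a higher number than compound 3 by roughly a 1.7-fold higher number from compound 3 to compound 4 (0.24 log units; within the scatter). The expected value for compound 4 is 35 ug/mL, with a range from 15 ug/mL to 80 ug/mL.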

Compound 4, half-maximal cytotoxic concentration: 34.5 ug/mL
For compound 4 the middle estimate is 1.0-fold (0.01 log units) above the measured one; measured number inside the range.
By their numbers in this assay, from the lowest: compounds 3, 4 and 2 (each within the scatter of the next, the first and the last beyond it); then compound 1.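

In this assay the exchange of chloro for methoxy on an aromatic carbon, para to a large group, can now be read on its own with the chain held fixed: it gives a 1.7-fold higher number from compound 3 to compound 4 (0.23 log units; within the scatter) and so does not separate the two groups at this position. On the chain, methyl in place of hydrogen four bonds along from an aromatic carbon gives a 1.7-fold lower number from compound 2 to compound 4 (0.24 log units; within the scatter) and does not separate those two compounds either, whereas the methyl three bonds along gave a 2.6-fold lower number from compound 1 to compound 2 (0.41 log units; beyond the scatter) and did. Ethyl in place of hydrogen three bonds along gives a 4.4-fold lower number from compound 1 to compound 4 (0.65 log units; beyond the scatter) as the whole span of the methoxy compounds, so the shift with chain length in this set rests on the step out of compound 1 and on that span. No measurement at hand explains any of these steps.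

Going by these compounds, whether chloro and methoxy also stay within the scatter of each other on the shorter chains of compound 1 and compound 2 remains open. Also open, on these data alone, is how a longer chain such as hexyl, or an amine or a carboxylic acid in place of methoxy on the same aromatic carbon, would read in this assay on the shared core.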